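From Compound 3 to Compound 4: One Group Exchanged

The source may report more compounds than this note shows. Statements on the series, on what has been measured and on what is new or still open speak of the compounds shown alone.

In a functional assay on DU-145 cells (Homo sapiens) for inhibition, read by trypan blue exclusion, with a stated time of 96 h (on this read-out lower numbers stand for stronger inhibition of growth and higher numbers for weaker inhibition of growth), compound 3 `CN(C)c1ccc(/C=C(/SCc2ccc(Cl)cc2)C(=O)c2ccc(Br)cc2)cc1` gives 10000 nM, level with compound 1 `COc1ccccc1/C=C(/SCc1ccc(Cl)cc1)C(=O)c1ccc([N+](=O)[O-])cc1` at 10000 nM, and these two share the highest number of the three. Compound 2 `O=C(/C(=C\c1cc(Cl)cc(Cl)c1Cl)SCc1ccc(Cl)cc1)c1ccc(Br)cc1` gives 1000 nM. Compound 4 `COc1ccccc1/C=C(/SCc1ccc(Cl)cc1)C(=O)c1ccc(Br)cc1` differs from compound 3 in one group, 2-methoxyphenyl in place of 4-(dimethylamino)phenyl on a double-bonded chain carbon bound to a double-bonded chain carbon: 2-methoxyphenyl replaces 4-(dimethylamino)phenyl on a double-bonded chain carbon bound to a double-bonded chain carbon. Within the data shown here, the only measured step at this place, a 10-fold higher number from compound 2 to compound 3 (1.00 log units; beyond the scatter), is modest but beyond the scatter, and it involves a different group. Compound 1 already carries 2-methoxyphenyl, though it differs elsewhere, and gives 10000 nM, so no large shift is expected. The estimated step is small, a 1.4-fold lower number from compound 3 to compound 4 (0.15 log units; within the scatter). For compound 4 the expected value is 7000 nM, with an estimated range from 2000 nM to 20000 nM.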

Compound 4, concentration for 50% growth inhibition: 1000 nM
Estimate against measurement, compound 4: 7.0-fold (0.85 log units) above; the measured number lies below the stated range.
By their numbers in this assay, from the lowest: compounds 2 and 4 (each within the scatter of the next); then compounds 1 and 3 (each within the scatter of the next).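

At this place, 2-methoxyphenyl replacing 4-(dimethylamino)phenyl brings a 10-fold lower number from compound 3 to compound 4 (1.00 log units; beyond the scatter) and 2-methoxyphenyl replacing 2,3,5-trichlorophenyl brings no change at the digits printed from compound 2 to compound 4 (within the scatter) so among these three groups only 4-(dimethylamino)phenyl stands apart. Bromo in place of nitro on an aromatic carbon brings a 10-fold lower number from compound 1 to compound 4 (1.00 log units; beyond the scatter) and this shows that 2-methoxyphenyl alone does not set the high number of compound 1. Nothing measured here explains these steps. As far as these compounds go, whether a plain phenyl, or a ring carrying a carboxylic acid or an amine, would sit level with compound 2 and compound 4 stays open, as does the exchange of bromo for chloro or methyl.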